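This account rests on a few compounds, and the source may have more. Where it says the series, first, only, none or still open, it means among the compounds named here.

Compound 2 `CC(C)N(Cc1cccc(OCCCCCC(=O)O)c1)C(=O)c1ccc(-c2ccoc2)cc1` shares its core with compound 1 `CC(C)COc1cccc(-c2ccc(C(=O)N(Cc3cccc(OCCCCCC(=O)O)c3)C(C)C)cc2)c1` and with compound 3 `CC(C)N(Cc1cccc(OCCCCCC(=O)O)c1)C(=O)c1ccc(-c2cccc(OCc3ccccc3)c2)cc1`; the three differ only in the group attached at one aromatic carbon or at the far end of an ether. In an ADME assay on HEK293 cells (Homo sapiens) for cytotoxicity, read by CellTiter-Glo and resazurin assay, with a stated time of 72 h (a higher number here means that more compound is needed for the effect, a lower number that less compound is needed), compound 2 gives > 26000 nM, which is a limit rather than a number. Compound 1 gives > 26000 nM, again a limit. Compound 3 gives > 26000 nM, also a limit. All three sit at the limit of > 26000 nM in this assay, at which 3 of the 3 values shown sit, so no order among them can be read, and both the step that the two limits leave unreadable from compound 1 to compound 2 and the step that the two limits leave unreadable from compound 1 to compound 3 stay of unknown size.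

Compound 4 `CC(C)N(Cc1cccc(OCCCCCC(=O)O)c1)C(=O)c1ccc(-c2ccc3c(c2)OCCO3)cc1` differs from compound 2 by one change: 2,3-dihydro-1,4-benzodioxin-6-yl in place of furan-3-yl on an aromatic carbon. Among the measured compounds shown here, the measured step that touches the same position is a step that the two limits leave unreadable from compound 1 to compound 2, and its size cannot be read; the only guide is that every compound measured so far reaches the limit. No step beyond the scatter is therefore expected in this assay in either direction. The step of a number no higher from compound 2 to compound 4 (the limit leaves the size open) is expected to be essentially none. Compound 4 is estimated at 26000 nM, with an expected range from 13000 nM to 60000 nM.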

Compound 4, half-maximal effective concentration: > 21900 nM
Compound 4: a limit, no number; the forecaster's own chance of this, stated with the estimate: 80%; the middle value lies beyond the limit too.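

In this assay compound 4 gives > 21900 nM, which is a limit and not a number. Neither the step from compound 1 to compound 4 nor the step from compound 2 to compound 4 can be read. The compounds shown leave open at what concentration any of them affects these cells, and whether the group on that aromatic carbon matters.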